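The compounds below may be only part of what the source reports. "The series", "measured", "known", "first", "only" and "open" are said of these compounds alone.

Compound 2 `CC(C)c1cccc(OC(=O)c2cn(-c3ccccc3)nc2-c2cccnc2)c1` and compound 1 `O=C(c1cn(-c2ccccc2)nc1-c1cccnc1)N1CCC(Cc2ccccc2)CC1` share the same core and differ in what hangs from the carbonyl. In a functional assay on MCF7 cells (Homo sapiens) for cytotoxicity, read by MTT assay, with a stated time of 48 h (on this read-out lower numbers stand for stronger inhibition and higher numbers for weaker inhibition), compound 2 gives 75500 nM, the higher of the two numbers, while compound 1 gives 32200 nM, a gap beyond the usual scatter. Compound 3 `Cc1ccc(C(C)C)c(OC(=O)c2cn(-c3ccccc3)nc2-c2cccnc2)c1` carries 2-isopropyl-5-methylphenyl in place of 3-isopropylphenyl on an oxygen next to a carbonyl group, leaving everything else unchanged. Nothing measured here shows how such a change moves this assay, so the step of a 1.1-fold lower number from compound 2 to compound 3 (0.03 log units; within the scatter) is expected to stay within the scatter, with no clear direction. Compound 3 is therefore estimated at 70000 nM, with a range from 25000 nM to 200000 nM.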

Compound 3, half-maximal inhibitory concentration: 84200 nM
Estimate against measurement, compound 3: 1.2-fold (0.08 log units) below, and the stated range covers the measured number.
By their numbers in this assay, from the lowest: compound 1; then compounds 2 and 3 (each within the scatter of the next).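

In this assay, putting 2-isopropyl-5-methylphenyl in place of 3-isopropylphenyl on this oxygen gives a 1.1-fold higher number from compound 2 to compound 3 (0.05 log units; within the scatter), so adding to and rearranging the alkyl groups on this aromatic ring produces no readable change. The earlier compounds shown here showed only a difference in what hangs from the carbonyl, not a step within this family of aryl groups. Nothing available accounts for this result. The compounds shown leave open whether a group carrying an amine or a carboxylic acid on this oxygen would move the number beyond the scatter.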